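A Cyclobutyl Group Gives Way to Propyl

A few compounds are considered here, and "the series" means these few. Any claim that something is new, unique, unknown or untested is made for them only; others in the source may bear on it.

In an ADME assay on the whole organism (plasma, Homo sapiens) for protein binding, read by LC-MS, with a stated time of 24 h (a lower number here means a smaller unbound share, a higher number a larger unbound share of the compound), compound 2 (`Cc1nc(-c2nnn(C)c2COC(=O)N(C)CC2CCC2)ccc1O[C@H]1CCC[C@H](C(=O)O)C1`) stands at 0.033 and compound 3 (`CN(C(=O)OCc1c(-c2ccc(O[C@H]3CCC[C@H](C(=O)O)C3)cn2)nnn1C)C1CCCC1`) at 0.025 within the scatter of it. Among the compounds with values here, compound 1 (`CN(CC1CCC1)C(=O)OCc1c(-c2ccc(O[C@H]3CCC[C@H](C(=O)O)C3)c(C(F)F)n2)nnn1C`) lies far lower at 0.001 and the one measured single-place step (a 33-fold higher number from compound 1 to compound 2 (1.52 log units; beyond the scatter)) puts methyl in place of difluoromethyl on an aromatic carbon. That step is large, but it sits at a different place from the change in compound 4 (`CCCCN(C)C(=O)OCc1c(-c2ccc(O[C@H]3CCC[C@H](C(=O)O)C3)c(C)n2)nnn1C`), which has propyl in place of cyclobutyl on a saturated chain carbon bound to an amide-type nitrogen. Within the data shown here, no measured step covers that place, so no shift beyond the scatter is expected in this assay and the expected move (a 1.1-fold lower number from compound 2 to compound 4 (0.04 log units; within the scatter)) is small. For compound 4 the estimated unbound fraction is 0.03 (expected range 0.014 to 0.06).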

Compound 4, unbound fraction: 0.026
For compound 4 the middle estimate is 1.2-fold (0.06 log units) above the measured one, and the stated range covers the measured number.
By their numbers in this assay, from the lowest: compound 1; then compounds 3, 4 and 2 (each within the scatter of the next).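

Within the data shown here, the first measured step at this place (a 1.3-fold lower number from compound 2 to compound 4 (0.10 log units; within the scatter)) shows that, in this assay, replacing cyclobutyl with propyl on a saturated chain carbon bound to an amide-type nitrogen leaves the unbound fraction within the scatter. Opening this ring therefore has no readable effect here, unlike the large step on the aromatic carbon (a 33-fold higher number from compound 1 to compound 2 (1.52 log units; beyond the scatter)). No measurement offered here explains this result.

From the compounds shown here alone, whether a longer chain or a terminal amine at this place would also stay within the scatter remains open. So does whether butyl behaves the same with difluoromethyl in place of methyl.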